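Indolyl for difluorophenyl on an acrylamide pyrimidine series

This account rests on a few compounds, and the source may have more. Where it says the series, first, only, none or still open, it means among the compounds named here.

Three compounds share one core and were tested in an ADME assay on HT-29 cells (Homo sapiens) for inhibition, read by MTT assay, with a stated time of 72 h; on this read-out higher numbers stand for weaker inhibition and lower numbers for stronger inhibition. Compound 1 `C=CC(=O)Nc1cccc(Nc2nc(N/N=C/c3ccc(F)cc3F)ncc2Cl)c1` gives 4760 nM. Compound 2 `C=CC(=O)Nc1cccc(Nc2nc(N/N=C(\C)c3ccc(C)cc3)ncc2Cl)c1` gives 3210 nM, and the step of a 1.5-fold lower number from compound 1 to compound 2 (0.17 log units; within the scatter) swaps the group on the hydrazine nitrogen. Compound 3 `CN(C)C/C=C/C(=O)Nc1cccc(Nc2nc(N/N=C/c3ccc(F)cc3F)ncc2Cl)c1` gives 2920 nM; the step of a 1.6-fold lower number from compound 1 to compound 3 (0.21 log units; within the scatter) changes only the amide side chain. Compound 3 thus sits alongside compound 2 and compound 1, with neither gap going beyond the scatter.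

Compound 4 `CN(C)C/C=C/C(=O)Nc1cccc(Nc2nc(N/N=C/c3c[nH]c4ccccc34)ncc2Cl)c1` is not yet measured. It differs from compound 3 by 1H-indol-3-yl in place of 2,4-difluorophenyl on a carbon with a double bond to nitrogen. Within the data shown here, the one measured step at the same position, a 1.5-fold lower number from compound 1 to compound 2 (0.17 log units; within the scatter), exchanged one ring-bearing group for another and stayed within the scatter, while a 1.6-fold lower number from compound 1 to compound 3 (0.21 log units; within the scatter) was likewise small. Nothing here points to a large effect from a change at this position, so compound 4 is expected to show a step of a 1.2-fold lower number from compound 3 to compound 4 (0.07 log units; within the scatter) in this assay, not beyond the scatter. The value of compound 4 is therefore estimated at 2500 nM, within a range from 900 nM to 7000 nM.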

Compound 4, half-maximal inhibitory concentration: 9680 nM
For compound 4 the middle estimate is 3.9-fold (0.59 log units) below the measured one, outside the stated range (above it).
By their numbers in this assay, from the lowest: compounds 3, 2 and 1 (each within the scatter of the next); then compound 4.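

In this assay, among these compounds, the change to 1H-indol-3-yl in place of 2,4-difluorophenyl on a carbon with a double bond to nitrogen gives a 3.3-fold higher number from compound 3 to compound 4 (0.52 log units; beyond the scatter) and is the only step in this set to pass beyond the scatter, so this part of the molecule does respond to the group it carries, which a 1.5-fold lower number from compound 1 to compound 2 (0.17 log units; within the scatter) did not reveal. The change is toward weaker inhibition, and it brings together a second aromatic ring, a hydrogen-bond donor and the loss of both fluorines, which this one step cannot separate. No measurement shown here accounts for the rise in the number.

Still open, as far as these compounds go, is whether 1-methylindol-3-yl, which lacks the ring hydrogen-bond donor, or a naphthyl group would give a similar number. Also open, from the compounds shown here alone, is whether 1H-indol-3-yl has the same effect when the amide carries the vinyl group of compound 1.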